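From Compound 1 to Compound 4: An Expected Step

The source may report more compounds than this note shows. Statements on the series, on what has been measured and on what is new or still open speak of the compounds shown alone.

Compound 1 `COc1ccc(-c2nc(CNC(=O)c3cccnc3)sc2-c2ccc(OC)cc2)cc1`: 8.2 uM
Compound 2 `COc1ccc(-c2nc(C(=O)N3CCN(C(=O)NC(C)C)CC3)sc2-c2ccc(OC)cc2)cc1`: 15 uM
Compound 3 `CCOC(=O)C1=C(C)N=C(C)/C(=C(/O)OCC)C1c1nc(-c2ccc(OC)cc2)c(-c2ccc(OC)cc2)s1`: > 32 uM

Of the compounds shown here, three sharing a core have been tested in a functional assay (aorta) with Rattus norvegicus as the target; on this read-out lower numbers stand for an effect already at smaller amounts and higher numbers for an effect only at larger amounts of compound. Compound 1 gives 8.2 uM, the lowest of the two numbers reported. Compound 2 gives 15 uM, which sits within the scatter of compound 1, so the two cannot be ordered. For compound 3 the assay reports only a limit, > 32 uM; this is the case described by the limit of > 32 uM in this assay, at which 1 of the 3 values shown sits.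

Compound 4 `COc1ccc(-c2nc(C3=CCN(C)CC3)sc2-c2ccc(OC)cc2)cc1` has not yet been measured. It differs from compound 1 as follows: a group of 7 heavy atoms (6 carbon, 1 nitrogen; one six-membered non-aromatic ring with 1 hetero atom) in place of a group of 10 heavy atoms (7 carbon, 2 nitrogen, 1 oxygen; one six-membered aromatic ring with 1 hetero atom), on an aromatic carbon. Within the data shown here, no pair of measured compounds differs in a single place, so the size of such a change in this assay is unknown here. Any direction for the step is therefore an expectation without a measured anchor. On the values shown, compound 4 is expected to land near compound 1, at about 10 uM, plausibly between 2.5 uM and 40 uM. The expected step of a 1.2-fold higher number from compound 1 to compound 4 (0.09 log units; within the scatter) is estimated to lie within the scatter.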

Compound 4, concentration for half-maximal effect: 5.9 uM
Compound 4: the middle estimate sits 1.7-fold (0.23 log units) above what was measured, and the stated range covers the measured number.
By their numbers in this assay, from the lowest: compounds 4, 1 and 2 (each within the scatter of the next, the first and the last beyond it). At a limit, above all of these: compound 3.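

In this assay, among these compounds, the first step that can be read at this position is a 1.4-fold lower number from compound 1 to compound 4 (0.14 log units; within the scatter). The aromatic carbon next to the ring nitrogen and next to the ring sulfur therefore accepts a six-membered non-aromatic ring with one hetero atom in place of (((pyridin-3-yl)carbonyl)amino)methyl with no difference beyond the scatter, even though the aromatic ring and the only hydrogen-bond donor of that group are gone. Nothing measured here gives a reason for this step.

From the compounds shown here alone, what a plain methyl or a carboxylic acid on this carbon would give remains open. So does the contribution of the methyl on the ring nitrogen of compound 4, which a hydrogen or an ethyl in its place would address.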